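The source may hold more compounds than are shown below. What is called first, only, known or untested is meant among the compounds shown, and "the series" means these compounds.

In a functional assay on M14 cells (Homo sapiens) for antiproliferative activity, with a stated time of 72 h (on this read-out higher numbers stand for weaker inhibition and lower numbers for stronger inhibition), compound 1 `C=CC[C@H]1C[C@]2([C@@H](C)Cc3ccc(OC)c(OC)c3)OCOC2=CC1=O` gives 110 nM, and compound 2 `C=CC[C@H]1C[C@]2([C@@H](C)Cc3ccc(OC)nc3)OCOC2=CC1=O` gives 180 nM. The difference between their two cores is not broken down here. Compound 3 `C=CC[C@H]1C[C@]2([C@@H](C)Cc3cnc(OC)cc3F)OCOC2=CC1=O` carries fluoro in place of hydrogen on an aromatic carbon, and this change gave a 44-fold higher number from compound 2 to compound 3 (1.65 log units; beyond the scatter), so that compound 3 gives 8000 nM. Compound 4 `C=CC[C@H]1C[C@]2([C@@H](C)Cc3cc(OC)c(OC)cc3F)OCOC2=CC1=O` carries fluoro in place of hydrogen on an aromatic carbon. This is the same kind of change as that from compound 2 to compound 3, but not the same: in compound 3 the fluoro sits on a six-membered aromatic ring with 1 nitrogen, opposite the ring nitrogen, whereas in compound 4 it sits on a six-membered aromatic ring of carbon only, para to a methoxy group. Among the compounds with values here, compound 4 is expected to show a 32-fold higher number from compound 1 to compound 4 (1.50 log units; beyond the scatter), a step near the size of the earlier one, because a 44-fold higher number from compound 2 to compound 3 (1.65 log units; beyond the scatter) is the only measured example of this change. Compound 4 is therefore estimated at 3500 nM, likely between 700 nM and 15000 nM.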

Compound 4, half-maximal inhibitory concentration: 14 nM
For compound 4 the middle estimate is 250-fold (2.40 log units) above the measured one; measured number outside the range, below it.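

In this assay the fluoro in place of hydrogen gave a 7.9-fold lower number from compound 1 to compound 4 (0.90 log units; beyond the scatter). The same change thus moved the number in opposite directions on the two cores, by a gap larger than the usual scatter: the same change on two cores in this assay, a 44-fold higher number (1.65 log units; beyond the scatter) from compound 2 to compound 3 and a 7.9-fold lower number (0.90 log units; beyond the scatter) from compound 1 to compound 4, 350-fold (2.54 log units) apart, beyond the scatter of two such steps

Within the data shown here, this shows that the result of this change cannot be carried from one core to the other, but it does not show why, since only two pairs are compared and the cores differ in more than one place.

From the compounds shown here alone, whether a chloro or a methyl group on the same aromatic carbon would act like the fluoro of compound 4 remains open. So does the result of an amine in place of either methoxy group.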